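Cyclopropyl to 4,4-difluorocyclohexyl: one step in the series

The source may hold more compounds than are shown below. What is called first, only, known or untested is meant among the compounds shown, and "the series" means these compounds.

Measured compounds:
compound 1 `NC1CCN(C2CN(CC[C@]3(c4ccc(Cl)c(Cl)c4)CCC(=O)N(CC4CC4)C3)C2)CC1` — 2 nM
compound 2 `CS(=O)(=O)N1CCN(C2CN(CC[C@]3(c4ccc(Cl)c(Cl)c4)CCC(=O)N(CC4CC4)C3)C2)CC1` — 3.16 nM

In a functional assay with Substance-K receptor (Oryctolagus cuniculus) as the target (on this read-out higher numbers stand for weaker binding and lower numbers for tighter binding), compound 1 gives 2 nM and compound 2 gives 3.16 nM. The step of a 1.6-fold higher number from compound 1 to compound 2 (0.20 log units; within the scatter) is within the scatter, so compound 2 carries the higher of the two numbers without being separated from compound 1.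

Compound 3 `CS(=O)(=O)N1CCN(C2CN(CC[C@]3(c4ccc(Cl)c(Cl)c4)CCC(=O)N(CC4CCC(F)(F)CC4)C3)C2)CC1` differs from compound 2 by 4,4-difluorocyclohexyl in place of cyclopropyl on a saturated chain carbon bound to an amide-type nitrogen in a ring. Among the compounds with values here, the one measured step concerns the group on a saturated ring carbon at the other end of the molecule and does not touch the position changed here; there is no measured step that bears on this change, and the data give no direction for it.

With nothing to point either way, the expectation for this assay is a step that stays within the scatter, in no particular direction. Compound 3 is therefore estimated at 3.2 nM, with a range from 0.8 nM to 13 nM. That estimate corresponds to an expected step of a 1.0-fold higher number from compound 2 to compound 3 (0.01 log units; within the scatter).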

Compound 3, dissociation constant: 1 nM
Beside the measured number, compound 3's estimate is 3.2-fold (0.51 log units) above it; the measured number falls inside the stated range.
By their numbers in this assay, from the lowest: compounds 3, 1 and 2 (each within the scatter of the next, the first and the last beyond it).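

In this assay, within the data shown here, the change from cyclopropyl to 4,4-difluorocyclohexyl gives a 3.2-fold lower number from compound 2 to compound 3 (0.50 log units; beyond the scatter) and is the first step to lie beyond the scatter. On a saturated chain carbon bound to an amide-type nitrogen in a ring, this single pair shows that a ring of 8 heavy atoms in place of one of 3 costs no binding and modestly tightens it. Nothing measured accounts for this step.

Going by these compounds, it remains open whether the step follows the larger ring or the two fluorines, which plain cyclohexyl would separate, and how an amine or a carboxylic acid on that ring would read. Also open, on these data alone, is whether the step holds with 4-aminopiperidin-1-yl, as in compound 1, in place of 4-(methylsulfonyl)piperazin-1-yl.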